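The source may hold more compounds than are shown below. What is called first, only, known or untested is meant among the compounds shown, and "the series" means these compounds.

Compound 1 `CC(c1cc2cccnc2cc1F)n1cnc2ncc(-c3ccc(C(N)=O)c(F)c3)nc21`: 19.5 nM
Compound 2 `CC(NC/N=C/c1ccnn1C)c1ccc2ncccc2c1`: 3290 nM

In a functional assay on NCI-H1993 cells (Homo sapiens) for inhibition, read by CCK-8 assay, with a stated time of 72 h (on this read-out higher numbers stand for weaker inhibition and lower numbers for stronger inhibition), compound 2 holds the higher of the two numbers. Compound 2 gives 3290 nM and compound 1 gives 19.5 nM. The gap between these two compounds lies beyond the scatter, so compound 2 is the weaker inhibitor of the pair. The next compound to be tested is compound 3 `CC(NC/N=C/C1=CCNCC1)c1ccc2ncccc2c1`, which differs from compound 2 in one place, on a carbon with a double bond to nitrogen: a group of 6 heavy atoms (5 carbon, 1 nitrogen; one six-membered non-aromatic ring with 1 hetero atom) in place of a group of 6 heavy atoms (4 carbon, 2 nitrogen; one five-membered aromatic ring with 2 hetero atoms), on a carbon with a double bond to nitrogen. For the measured compounds named here, no measured pair shows what such an exchange does in this assay, so the expectation starts from compound 2 and stays wide. An estimated 1.2-fold higher number from compound 2 to compound 3 (0.08 log units; within the scatter) is expected, which means no step beyond the scatter in either direction. For compound 3 the expected value is 4000 nM and the estimated range runs from 1000 nM to 15000 nM as the measurement is awaited.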

Compound 3, half-maximal inhibitory concentration: 2660 nM
Estimate against measurement, compound 3: 1.5-fold (0.18 log units) above, within the range that was stated.
By their numbers in this assay, from the lowest: compound 1; then compounds 3 and 2 (each within the scatter of the next).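

In this assay, putting the six-membered non-aromatic ring with 1 hetero atom in place of 1-methyl-1H-pyrazol-5-yl, on a carbon with a double bond to nitrogen, gives a 1.2-fold lower number from compound 2 to compound 3 (0.09 log units; within the scatter). At this position, then, this read-out does not separate the two rings, even though they differ in ring size and in being aromatic or non-aromatic. Nothing at hand accounts for this result.

For the compounds shown here, the two rings show only that this one exchange leaves the number within the scatter, so it remains open whether a carboxylic acid, an open-chain amine or a longer chain on this carbon would do the same. Compound 1 differs from compound 2 and compound 3 in more than one place, so the gap separating it from them cannot be traced to this position.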